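Cyclopropyl in Place of Isopropyl at the Ether Side Chain

A few compounds are considered here, and "the series" means these few. Any claim that something is new, unique, unknown or untested is made for them only; others in the source may bear on it.

Compound 1 `c1cc(OC2CCCCC2)nc(N2CCNCC2)c1`: 30 mg/kg
Compound 2 `CCOc1cccc(N2CCNCC2)n1`: 30 mg/kg
Compound 3 `CC(C)COc1cccc(N2CCNCC2)n1`: 10 mg/kg

Three compounds sharing one core were tested in a functional assay on the whole organism with Mus musculus as the target, in the maximal electroshock model, with a stated time of 30 min; a higher number here means that more compound is needed for the effect, a lower number that less compound is needed. Compound 3 gives the lowest number of the three, and its distance from both neighbours is beyond the scatter: a 3.0-fold lower number from compound 1 to compound 3 (0.48 log units; beyond the scatter) and a 3.0-fold lower number from compound 2 to compound 3 (0.48 log units; beyond the scatter). Compound 1 and compound 2, by contrast, sit together, as no change at the digits printed from compound 1 to compound 2 (within the scatter) shows.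

The next compound, compound 4 `c1cc(OCC2CC2)nc(N2CCNCC2)c1`, differs from compound 3 in one place: cyclopropyl in place of isopropyl on a saturated chain carbon bound to an oxygen on an aromatic ring

The step that bears most directly on this change is the one that altered the same saturated chain carbon before, a 3.0-fold lower number from compound 2 to compound 3 (0.48 log units; beyond the scatter), where a larger branch on that carbon brought a modest gain. The move from compound 1 to compound 3 shows that a cyclic group on the oxygen is not required for the effect. Here the branch keeps the same count of heavy atoms and merely closes into a three-membered ring, so compound 4 is expected to sit near compound 3, with an expected step of no change at the digits printed from compound 3 to compound 4 (within the scatter), that is, nothing beyond the scatter in this assay. Compound 4 is therefore estimated at 10 mg/kg, within a range of 3 mg/kg to 30 mg/kg.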

Compound 4, minimum effective dose: 10 mg/kg
Estimate against measurement, compound 4: no gap at the digits printed; the measured number falls inside the stated range.
By their numbers in this assay, from the lowest: compounds 3 and 4 (each within the scatter of the next); then compounds 1 and 2 (each within the scatter of the next).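

In this assay, closing the isopropyl into a cyclopropyl on the saturated chain carbon bound to the oxygen leaves the reading in place, with no change at the digits printed from compound 3 to compound 4 (within the scatter), so at this position an open branch and a three-membered ring of the same heavy-atom count cannot be told apart. The lower number is therefore not confined to the isobutyl group of compound 3: cyclopropylmethyl gives a 3.0-fold lower number from compound 2 to compound 4 (0.48 log units; beyond the scatter) and a 3.0-fold lower number from compound 1 to compound 4 (0.48 log units; beyond the scatter), placing compound 3 and compound 4 together and apart from compound 1 and compound 2. No measurement is available that accounts for this equivalence of the two groups.

The compounds shown leave open whether a larger ring on the same saturated chain carbon, as in cyclobutylmethyl or cyclohexylmethyl, or an unbranched longer chain such as n-butyl, would stay with compound 3 and compound 4 or return to the level of compound 1 and compound 2. They also leave open how this side chain would tolerate a hydroxyl group, an amine or a fluorine atom placed on it.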